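Notes on compound 3: methoxy on the phenyl of compound 2

A few compounds are considered here, and "the series" means these few. Any claim that something is new, unique, unknown or untested is made for them only; others in the source may bear on it.

Compound 2 `CC(=O)c1cc(-c2ccc(F)cc2)cc2cc(-c3ccccc3)[nH]c12` stands highest of the two numbers in a functional assay on HeLa cells (Homo sapiens) for cytotoxicity, read by MTT assay, with a stated time of 2 days, tested at 0.1 uM (a lower number here means a stronger effect, a higher number a weaker effect of the compound at the concentration tested), giving 90.3%; compound 1 `CC(=O)c1cc(-c2ccccc2)cc2cc(-c3ccccc3)[nH]c12` gives 72.3% in this assay, a step of a number 18 percentage points higher from compound 1 to compound 2 (beyond the scatter). Compound 3 `COc1ccc(-c2cc3cc(-c4ccc(F)cc4)cc(C(C)=O)c3[nH]2)cc1` differs from compound 2 by methoxy in place of hydrogen on an aromatic carbon. No measured step covers a methoxy; the only step shown, a number 18 percentage points higher from compound 1 to compound 2 (beyond the scatter), concerns a different substituent and a different phenyl, so it bears on this change only loosely. The expected change in this assay is therefore a number 2.3 percentage points lower from compound 2 to compound 3 (within the scatter), none beyond the scatter. Compound 3 is estimated at 88%, within 74% to 100%.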

Compound 3, a percentage reported as activity, at one concentration (the size of the read-out at that concentration, not a potency): 81%
Compound 3: middle estimate off by 7 percentage points, on the high side; low and high end bracket the measured number.
By their numbers in this assay, from the lowest: compounds 1, 3 and 2 (each within the scatter of the next, the first and the last beyond it).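

In this assay, methoxy para to a large group gives a number 9.3 percentage points lower from compound 2 to compound 3 (within the scatter), so this change on the phenyl does not move the number beyond the scatter. Compounds 1 and 2 carry no substituent on this phenyl, so this is the only reading of the position shown. No measurement at hand offers an explanation for the step. As far as these compounds go, whether an amine, a carboxylic acid or a longer chain such as ethoxy in this place would go beyond the scatter remains open. So does the effect of methoxy on compound 1.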